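Ethyl to (pyrrolidin-1-yl)methyl on the shared core

A few compounds are considered here, and "the series" means these few. Any claim that something is new, unique, unknown or untested is made for them only; others in the source may bear on it.

Measured so far in a physicochemical assay for lipophilicity, at pH 7.4; on this read-out lower numbers stand for lower lipophilicity and higher numbers for higher lipophilicity:
- compound 1 `CCc1ccc2c(c1)C=CN(C)C(=O)[C@@H]2C`: 5.9
- compound 2 `CC1C(=O)N(C)C=Cc2cc(OCC(C)(C)O)ccc21`: 3.6

Compound 1 holds the higher of the two numbers in this assay, and compound 2 lies below it by a gap beyond the usual scatter. Compound 3 `C[C@H]1C(=O)N(C)C=Cc2cc(CN3CCCC3)ccc21` has not yet been measured. It differs from compound 1 as follows: pyrrolidin-1-yl in place of methyl on a saturated chain carbon bound to an aromatic carbon. Pyrrolidin-1-yl takes the place of methyl on a saturated chain carbon bound to an aromatic carbon, so ethyl becomes (pyrrolidin-1-yl)methyl. Among the compounds with values here, no measured pair isolates this change, so any forecast remains loose. Within the data shown here, the reading of compound 2 at 3.6 shows only that a compound with this core can lie far lower than compound 1 does. A large downward step in this assay, beyond the scatter, is therefore expected. The expected change is a number 2.70 log units lower from compound 1 to compound 3 (beyond the scatter). For compound 3 the estimated value is 3.2, with an expected range from 2.2 to 4.3.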

Compound 3, distribution coefficient: 1.5
Compound 3: middle estimate off by 1.70 log units, on the high side; measured number below the stated range.
By their numbers in this assay, from the lowest: compound 3; then compound 2; then compound 1.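

In this assay, replacing ethyl with (pyrrolidin-1-yl)methyl on the shared core gives a number 4.40 log units lower from compound 1 to compound 3 (beyond the scatter). This is the first pair that isolates a change at this place, on a saturated chain carbon bound to an aromatic carbon, and it shows that this single change can by itself move the read-out by a large step, where compound 2 had shown only that a compound with this core can lie far lower than compound 1. Nothing measured here explains the size of the step.

The compounds shown leave open whether the step belongs to pyrrolidin-1-yl in particular or would also come with another amine on that carbon, such as dimethylamino or morpholine. They also leave open how a carboxylic acid at the same place would read in this assay.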